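Metabolic stability notes on a thiazole-to-oxazole swap

The source may hold more compounds than are shown below. What is called first, only, known or untested is meant among the compounds shown, and "the series" means these compounds.

Measured so far:
compound 1 `Cc1cc2c(cc1Cc1ccc(-c3cscn3)cc1)C(=O)N([C@H]1CCOC[C@@H]1O)C2` — 10 mL/min/kg
compound 2 `Cc1nc(-c2ccc(Cc3cc4c(cc3C)CN([C@H]3CCOC[C@@H]3O)C4=O)cc2)co1` — 13 mL/min/kg
compound 3 `Cc1cc2c(cc1Cc1ccc(-c3cscn3)cc1)C(=O)N([C@H]1CCOC[C@@H]1O)CC2` — 25 mL/min/kg

In an ADME assay on microsomes from liver (Homo sapiens) for metabolic stability (a lower number here means slower removal, a higher number faster removal of the compound), compound 1 gives 10 mL/min/kg. Compound 2 differs from it only by the change (2-methyl-1,3-oxazol-4-yl in place of 1,3-thiazol-4-yl on an aromatic carbon), and the result of that change is a 1.3-fold higher number from compound 1 to compound 2 (0.11 log units; within the scatter). Compound 3 has a different core from compound 1; how the two cores differ is not broken down here. In this assay compound 3 gives 25 mL/min/kg, the highest of the three numbers, beyond the scatter relative to compound 1 but within it relative to compound 2.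

Compound 4 `Cc1nc(-c2ccc(Cc3cc4c(cc3C)CCN([C@H]3CCOC[C@@H]3O)C4=O)cc2)co1` is not yet measured. It stands to compound 3 as compound 2 stands to compound 1: the change is 2-methyl-1,3-oxazol-4-yl in place of 1,3-thiazol-4-yl on an aromatic carbon, the same change as before, at the same place. Among the compounds with values here, the only precedent for it is the step from compound 1 to compound 2, which stayed within the scatter, so for compound 4 a step of a 1.3-fold higher number from compound 3 to compound 4 (0.11 log units; within the scatter) is expected, resting on that single earlier step and on the value of compound 3. The estimate for compound 4 in this assay is 32 mL/min/kg, with a range from 18 mL/min/kg to 56 mL/min/kg.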

Compound 4, clearance: 21 mL/min/kg
Compound 4: the middle estimate sits 1.5-fold (0.18 log units) above what was measured, within the range that was stated.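

In this assay, 2-methyl-1,3-oxazol-4-yl in place of 1,3-thiazol-4-yl on the core of compound 3 gives a 1.2-fold lower number from compound 3 to compound 4 (0.08 log units; within the scatter). The step on this core does not differ from the earlier one, so for these two cores the change can be carried across as one that stays inside the scatter, and the opposite directions of the two steps carry no weight: the same change on two cores in this assay, a 1.3-fold higher number (0.11 log units; within the scatter) from compound 1 to compound 2 and a 1.2-fold lower number (0.08 log units; within the scatter) from compound 3 to compound 4, 1.5-fold (0.19 log units) apart, within the scatter of two such steps This is a result from two cores and one assay only; it gives no rule for other cores, and steps this small cannot show whether the change has a small real effect on either core.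

Open, as far as these compounds go, is whether a different group at the same place, para to a large group, such as an amine or a carboxylic acid, would move the number beyond the scatter. Also open, from the compounds shown here alone, is how a 1,3-oxazol-4-yl without the methyl group would read, which would separate the methyl group from the change of ring.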